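The source may hold more compounds than are shown below. What is called first, only, known or untested is meant among the compounds shown, and "the series" means these compounds.

Measured compounds:
- compound 1 `O=C(/C=C\c1ccccc1O)N1N=C(c2ccncc2)OC1c1c[nH]c2ccccc12`; in an ADME assay on HeLa cells (Homo sapiens) for cytotoxicity, read by MTT assay, with a stated time of 72 h (on this read-out lower numbers stand for stronger inhibition of growth and higher numbers for weaker inhibition of growth), compound 1 gives 26.8 ug/mL.
- compound 2 `O=C(/C=C\c1ccc(O)cc1)N1N=C(c2ccncc2)OC1c1c[nH]c2ccccc12`; for compound 2 only the assay limit is known, > 30 ug/mL.
- compound 3 `O=C(/C=C\c1cccc(F)c1)N1N=C(c2ccncc2)OC1c1c[nH]c2ccccc12`; for compound 3 likewise only the assay limit is known, > 30 ug/mL.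

Compound 3 thus stands at the limit of > 30 ug/mL in this assay, at which 2 of the 3 values shown sit, with no number of its own. The step to compound 4 `O=C(/C=C\c1ccc(Cl)cc1)N1N=C(c2ccncc2)OC1c1c[nH]c2ccccc12` is 4-chlorophenyl in place of 3-fluorophenyl on a double-bonded chain carbon bound to a double-bonded chain carbon. Of the measured steps, an at least 1.1-fold higher number from compound 1 to compound 3 (0.04 log units; that floor lies within the scatter) reaches only the limit floor, and a step that the two limits leave unreadable from compound 2 to compound 3 cannot be sized at all. Nothing here separates the aryl variants beyond the scatter, so no step beyond the scatter is expected in this assay. The expected step of a number no higher from compound 3 to compound 4 (the limit leaves the size open) is therefore flat, and compound 4 is estimated at 30 ug/mL, between 12 ug/mL and 75 ug/mL, most likely again reported only as a limit.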

Compound 4, concentration for 50% growth inhibition: > 30 ug/mL
Compound 4: no number, only a limit (the forecaster's own chance of this, stated with the estimate: 70%); the middle value sits exactly at the limit.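

In this assay compound 4 also gives only a limit, > 30 ug/mL. With 4-chlorophenyl in place of 3-fluorophenyl at this position, the series adds a chloro-substituted aryl group to those at the limit: the limit of > 30 ug/mL in this assay, at which 3 of the 4 values shown sit. Only an at least 1.1-fold higher number from compound 1 to compound 4 (0.04 log units; that floor lies within the scatter) can be sized, and the steps to compound 4 from compound 2 and compound 3 cannot be read.

On these data alone, whether an amine or a carboxylic acid in place of the chloro group would give a measurable value under the limit remains open. Any order among compound 2, compound 3 and compound 4 also remains open.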